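The source may hold more compounds than are shown below. What is called first, only, known or untested is meant among the compounds shown, and "the series" means these compounds.

Working notes on the series.

For the measured compounds named here, compound 3 `C[C@]1(CN2CCc3nc(-c4ccc(F)cc4F)ccc3C2)Cn2cc([N+](=O)[O-])nc2O1` carries the only single number so far in an ADME assay on Vero cells (Chlorocebus sabaeus) for cytotoxicity, read by MTT assay, with a stated time of 72 h (a higher number here means that more compound is tolerated, a lower number that less compound is tolerated), where compound 3 gives 12.5 ug/mL. In this assay compound 1 `C[C@]1(CN2CCc3nc(-c4ccccc4)ccc3C2)Cn2cc([N+](=O)[O-])nc2O1` reports a limit of the assay rather than a number, > 32 ug/mL. For compound 2 `C[C@]1(CN2CCc3nc(C(F)(F)F)ccc3C2)Cn2cc([N+](=O)[O-])nc2O1`, which carries a trifluoromethyl group in place of the aryl ring, this assay gives "not determined" (no result reported). Going by the values given here, the one measured step in this assay, an at least 2.5-fold lower number from compound 1 to compound 3 (0.40 log units; beyond the scatter), is bounded on one side by the limit (the limit of > 32 ug/mL in this assay, at which 1 of the 3 values shown sits), so its true size is not known beyond that lower bound.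

Compound 4 `C[C@]1(CN2CCc3nc(-c4cc(Cl)ccc4F)ccc3C2)Cn2cc([N+](=O)[O-])nc2O1` differs from compound 3 by 5-chloro-2-fluorophenyl in place of 2,4-difluorophenyl on an aromatic carbon. No measured step swaps one halogen pattern on the aryl ring for another; the only step shown, from compound 1 to compound 3, adds fluorines to a bare phenyl, and is therefore only loosely related. The expected step of a 1.3-fold lower number from compound 3 to compound 4 (0.10 log units; within the scatter) in this assay is accordingly small, within the scatter. In this assay compound 4 is expected to give 10 ug/mL, estimated between 4 ug/mL and 32 ug/mL.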

Compound 4, half-maximal cytotoxic concentration: > 32 ug/mL
Compound 4: a limit, no number (the forecaster's own chance of this, stated with the estimate: 15%); middle value at least 3.2-fold (0.50 log units) away from the limit.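

In this assay, the choice of halogen pattern on this aryl ring, on the aromatic carbon next to the ring nitrogen, can move the result: an at least 2.5-fold higher number from compound 3 to compound 4 (0.40 log units; beyond the scatter). Halogens as such therefore do not go with a lower number, since compound 4 also carries halogens and, among the aryl compounds shown, only the 2,4-difluorophenyl of compound 3 gives a single number. The step between compound 1 and compound 4 cannot be read, as each reports a limit of the assay rather than a number: the limit of > 32 ug/mL in this assay, at which 2 of the 4 values shown sit.

As far as these compounds go, how far compound 1 and compound 4 lie beyond that limit stays open, as does whether the chlorine or its place on the ring accounts for the step. Also open, from the compounds shown here alone, is how an aminomethyl group or a carboxylic acid on this aromatic carbon would read in this assay.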